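This account rests on a few compounds, and the source may have more. Where it says the series, first, only, none or still open, it means among the compounds named here.

Compound 3 `CN1C(=S)[C@@H](NC(=O)c2nc(Cc3ccccc3)n(CCCC#N)n2)COc2ccccc21` gives 2400 nM in a functional assay on HT-29 cells (Homo sapiens) for inhibition, read by luminescence and CellTiter-Glo, with a stated time of 24 h; a higher number here means that more compound is needed for the effect, a lower number that less compound is needed. It sits within the scatter of compound 2 `CN1C(=S)[C@@H](NC(=O)c2nc(Cc3ccccc3)n(CCCC(F)(F)F)n2)COc2ccccc21`, which gives 2380 nM, and of compound 1 `CN1C(=S)[C@@H](NC(=O)c2nc(Cc3ccccc3)n(CCCF)n2)COc2ccccc21`, which gives 4760 nM; the measured steps are a 2.0-fold lower number from compound 1 to compound 3 (0.30 log units; within the scatter), a 1.0-fold higher number from compound 2 to compound 3 (0.00 log units; within the scatter) and a 2.0-fold lower number from compound 1 to compound 2 (0.30 log units; within the scatter). Compound 4 `CN1C(=S)[C@@H](NC(=O)c2nc(Cc3ccccc3)n(CC3COC3)n2)COc2ccccc21` differs from compound 3 in one place: oxetan-3-yl in place of 2-cyanoethyl on a saturated chain carbon bound to an aromatic nitrogen. Within the data shown here, no measured step exchanges a chain end for a ring, so none bears directly on this change; the three steps that do vary this chain all stayed within the scatter, which suggests at most a small step in this assay, in either direction. Compound 4 is therefore estimated at 2400 nM, between 1000 nM and 6000 nM. The expected step is no change at the digits printed from compound 3 to compound 4 (within the scatter).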

Compound 4, half-maximal effective concentration: 2830 nM
For compound 4 the middle estimate is 1.2-fold (0.07 log units) below the measured one; the range from low to high includes it.
By their numbers in this assay, from the lowest: compounds 2, 3, 4 and 1 (each within the scatter of the next).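

In this assay, among these compounds, compound 4 puts a ring at this place, on a saturated chain carbon bound to an aromatic nitrogen, where the earlier compounds carry open chains, and the change gives a 1.2-fold higher number from compound 3 to compound 4 (0.07 log units; within the scatter) and a 1.2-fold higher number from compound 2 to compound 4 (0.08 log units; within the scatter) and a 1.7-fold lower number from compound 1 to compound 4 (0.23 log units; within the scatter) so that all four compounds lie within the scatter. Among these compounds, then, oxetan-3-yl reads the same as the nitrile and fluorinated chain ends. Nothing available explains this result.

The compounds shown leave open whether an amine, a carboxylic acid or a longer chain at this place would step beyond the scatter.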